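Sulfonyl in place of an amide on the shared core

The compounds below may be only part of what the source reports. "The series", "measured", "known", "first", "only" and "open" are said of these compounds alone.

Compound 1 `CCN(CC)c1ccc2cc(C(=O)c3ccc(N4CCN(C(=O)COc5ccc(Cl)cc5Cl)CC4)cc3)oc2c1` carries a ((2,4-dichlorophenoxy)methyl)carbonyl group on an amine nitrogen in a ring. In a functional assay on HeLa cells (Homo sapiens) for cytotoxicity, read by MTT assay, with a stated time of 48 h (a lower number here means a stronger inhibitor, a higher number a weaker inhibitor), compound 1 gives 30 nM, the lowest of the two plain numbers shown. Compound 2 `CCN(CC)c1ccc2cc(C(=O)c3ccc(N4CCN(S(=O)(=O)c5ccc(Br)cc5)CC4)cc3)oc2c1` carries (4-bromophenyl)sulfonyl at the same nitrogen instead, and in this assay compound 2 gives > 40000 nM, which is a limit of the assay and not a number. Compound 3 `CCN(CC)c1ccc2cc(C(=O)c3ccc(N4CCN(S(=O)(=O)c5ccc(F)cc5)CC4)cc3)oc2c1` carries (4-fluorophenyl)sulfonyl there, and in this assay compound 3 gives 21600 nM. Both steps away from compound 1 are large: an at least 1300-fold higher number from compound 1 to compound 2 (3.12 log units; beyond the scatter) and a 720-fold higher number from compound 1 to compound 3 (2.86 log units; beyond the scatter). Between the two sulfonyl compounds the difference is small: an at least 1.8-fold lower number from compound 2 to compound 3 (0.26 log units; that floor lies within the scatter).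

Compound 4 `CCN(CC)c1ccc2cc(C(=O)c3ccc(N4CCN(S(=O)(=O)c5ccc(Br)c(F)c5)CC4)cc3)oc2c1` has not yet been measured. It differs from compound 1 as follows: (4-bromo-3-fluorophenyl)sulfonyl in place of ((2,4-dichlorophenoxy)methyl)carbonyl on an amine nitrogen in a ring. This change resembles both measured sulfonyl steps, so a large rise in the number is expected, a 1200-fold higher number from compound 1 to compound 4 (3.07 log units; beyond the scatter). Because compound 2 already sits at the limit of > 40000 nM in this assay, at which 1 of the 3 values shown sits, a limit rather than a number is quite possible for compound 4 as well. The estimate for compound 4 is 35000 nM, with a range from 12000 nM to 100000 nM.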

Compound 4, half-maximal inhibitory concentration: 20700 nM
For compound 4 the middle estimate is 1.7-fold (0.23 log units) above the measured one; the range from low to high includes it.
By their numbers in this assay, from the lowest: compound 1; then compounds 4 and 3 (each within the scatter of the next). At a limit, above all of these: compound 2.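

Compound 4 carries two halogens on the aryl ring of its sulfonyl group, and the large gap to the amide of compound 1 remains in this assay, with a 690-fold higher number from compound 1 to compound 4 (2.84 log units; beyond the scatter), so all three sulfonyl compounds shown now stand far from compound 1 and none goes against this. Putting 4-bromo-3-fluorophenyl in place of 4-fluorophenyl on the sulfonyl sulfur leaves the two compounds level, with a 1.0-fold lower number from compound 3 to compound 4 (0.02 log units; within the scatter). The step with fluoro in place of hydrogen, an at least 1.9-fold lower number from compound 2 to compound 4 (0.28 log units; that floor lies within the scatter), starts from a limit of the assay and not a number, so it shows no clear change, and compound 2 alone stands at that limit: the limit of > 40000 nM in this assay, at which 1 of the 4 values shown sits.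

Every step away from compound 1 swaps the link to the nitrogen and the group behind it together, so the compounds shown leave open which of the two carries the gap, a question that a 4-fluorophenyl group joined through a carbonyl at this nitrogen could separate. Also open, on these data alone, is whether an amine or a carboxylic acid on the aryl ring of the sulfonyl group would move the number at all.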